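The source may report more compounds than this note shows. Statements on the series, on what has been measured and on what is new or still open speak of the compounds shown alone.

Measured in a physicochemical assay for lipophilicity, read by HPLC, measured as chromatographic lipophilicity, at pH 7.4; on this read-out lower numbers stand for lower lipophilicity and higher numbers for higher lipophilicity:

Compound 1 `N#Cc1ccc(N2CCC(C(=O)N3N=CC[C@H]3c3cc(F)cc(F)c3)CC2)nn1`: 4.8
Compound 2 `Cc1nnc(N2CCC(C(=O)N3N=CC[C@H]3c3ccccc3)CC2)o1`: 3.2
Compound 3 `N#Cc1cnc(N2CCC(C(=O)N3N=CC[C@H]3c3cc(F)cc(F)c3)CC2)cn1`: 5.2

Compound 3 stands highest of these three, with compound 1 nearest to it and compound 2 furthest away. The next compound, compound 4 `Cc1nnc(N2CCC(C(=O)N3N=CC[C@H]3c3cc(F)cc(F)c3)CC2)o1`, keeps the core of compound 3 and places 5-methyl-1,3,4-oxadiazol-2-yl in place of 5-cyanopyrazin-2-yl on an amine nitrogen in a ring.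

Among the compounds with values here, only one measured step touches this position. It is a number 0.40 log units higher from compound 1 to compound 3 (beyond the scatter), modest but beyond the scatter. That step exchanges one six-membered aromatic ring for another, so it gives little guidance on a change to a five-membered aromatic ring. Compound 2 says more, since it already carries the 5-methyl-1,3,4-oxadiazol-2-yl group and gives 3.2. However, its core has no fluorine, and no measured pair separates that difference from the change of group. In this assay a clear fall is therefore expected, though not the whole gap down to compound 2. The expected step is a number 1.30 log units lower from compound 3 to compound 4 (beyond the scatter), well beyond the scatter. The estimated value for compound 4 is 3.9, with an expected range from 3.4 to 4.4.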

Compound 4, distribution coefficient: 3.6
Compound 4: middle estimate off by 0.30 log units, on the high side; measured number inside the range.
By their numbers in this assay, from the lowest: compound 2; then compound 4; then compound 1; then compound 3.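

In this assay the change from a six-membered to a five-membered aromatic ring on the amine nitrogen proves large from either six-membered group, with a number 1.60 log units lower from compound 3 to compound 4 (beyond the scatter) and a number 1.20 log units lower from compound 1 to compound 4 (beyond the scatter) both exceeding the modest a number 0.40 log units higher from compound 1 to compound 3 (beyond the scatter) seen between the two six-membered groups. Compound 4 also supplies the single-change pair that was missing. Here 3,5-difluorophenyl in place of phenyl on a saturated ring carbon gives a number 0.40 log units higher from compound 2 to compound 4 (beyond the scatter) and so separates the fluorines from the group on the amine nitrogen, showing that of the two changes linking compound 3 to compound 2, the exchange of 5-cyanopyrazin-2-yl for 5-methyl-1,3,4-oxadiazol-2-yl is the larger step. Nothing available explains why these steps have the size they do.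

The compounds shown leave open whether the large fall belongs to the five-membered ring itself or to its methyl, which a 5-amino or 5-carboxylic acid version of the 1,3,4-oxadiazol-2-yl ring would help to settle. They also leave open whether the fluorine step keeps its size with 5-cyanopyrazin-2-yl on the amine nitrogen, since it has been read only with 5-methyl-1,3,4-oxadiazol-2-yl there.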